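The source may hold more compounds than are shown below. What is called first, only, known or untested is meant among the compounds shown, and "the series" means these compounds.

Measured compounds in an in vitro ADME assay on microsomes from liver (Homo sapiens) for pharmacokinetics, read by LC-MS, with a stated time of 10 min, tested at 1 uM; a lower number here means slower removal, a higher number faster removal of the compound:
- compound 1 `CN1C[C@H](C(=O)Nc2ccccc2)[C@@H](c2ccc(/C=C/C(=O)Nc3ccccc3N)cc2)C1`: 7 mL/min/kg
- compound 2 `CN1C[C@H](C(=O)Nc2ccc(C3CC3)cc2)[C@@H](c2ccc(/C=C/C(=O)Nc3ccccc3N)cc2)C1`: 12 mL/min/kg

Compound 1 gives the lowest of the two numbers in this assay; its nearest neighbour is compound 2, and the step of a 1.7-fold higher number from compound 1 to compound 2 (0.23 log units; within the scatter) lies within the scatter, so the two compounds cannot be ordered against each other on these data.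

The next compound, compound 3 `COc1cccc(NC(=O)[C@H]2CN(C)C[C@@H]2c2ccc(/C=C/C(=O)Nc3ccccc3N)cc2)c1`, has not yet been measured in this assay. It differs from compound 1 by methoxy in place of hydrogen on an aromatic carbon

Going by the values given here, only one measured step bears on this, the substitution on the same aromatic ring from compound 1 to compound 2, a 1.7-fold higher number from compound 1 to compound 2 (0.23 log units; within the scatter), which stayed within the scatter. The methoxy group entering in compound 3 is not the cyclopropyl group entering in compound 2, so that step is a loose guide at best. Among the compounds with values here, no other step touches this ring.

On that basis the step from compound 1 to compound 3 in this assay is expected to be small, a 1.4-fold higher number from compound 1 to compound 3 (0.15 log units; within the scatter), with no direction beyond the scatter. Compound 3 is therefore estimated at 10 mL/min/kg in this assay, with a range of 5 mL/min/kg to 20 mL/min/kg.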

Compound 3, clearance: 14 mL/min/kg
The estimate for compound 3 lay 1.4-fold (0.15 log units) below the measured number; the range from low to high includes it.
By their numbers in this assay, from the lowest: compounds 1, 2 and 3 (each within the scatter of the next).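

In this assay, methoxy in place of hydrogen on an aromatic carbon, meta to a large group, leaves the two compounds within the scatter of each other (a 2.0-fold higher number from compound 1 to compound 3 (0.30 log units; within the scatter)). With 3-methoxyphenyl in place of 4-cyclopropylphenyl on the amide-type nitrogen, the numbers again cannot be told apart (a 1.2-fold higher number from compound 2 to compound 3 (0.07 log units; within the scatter)), so neither of the two groups placed on this ring so far, one with a ring and one without, is separated from hydrogen or from the other group on these data. No measurement at hand bears on a cause for these numbers.

From the compounds shown here alone, it remains open whether a carboxylic acid, an amine or trifluoromethyl on this same ring would give a step beyond the scatter in this assay. Going by these compounds, it also remains open whether methoxy on another part of the shared core would behave as it does here, since all three compounds differ only on this one ring.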